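The source may report more compounds than this note shows. Statements on the series, on what has been measured and on what is new or still open speak of the compounds shown alone.

In an ADME assay on cells (Hepatocyte, Rattus norvegicus, strain Wistar) for pharmacokinetics, read by LC-MS, with a stated time of 90 min, tested at 1 uM (on this read-out lower numbers stand for slow clearance and higher numbers for fast clearance), compound 1 (`COc1cc(C(=O)N2CCC(O)C(C)C2)cc2nc(NCc3cccc(Cl)c3)oc12`) gives 45 mL/min/kg. Among the measured compounds shown here, compound 2 (`COc1cc(C(=O)N2CCC(O)C(C)C2)cc2nc(NC3(c4cccc(Cl)c4)CC3)oc12`) gives 46.7 mL/min/kg, and the two numbers lie within the scatter of each other, leaving compound 1 level with the only other measured member of the series. For the measured compounds named here, the single measured step is a 1.0-fold higher number from compound 1 to compound 2 (0.02 log units; within the scatter), with 1-(3-chlorophenyl)cyclopropyl in place of 3-chlorobenzyl on a nitrogen on an aromatic ring.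

Compound 3 (`COc1cc(C(=O)N2CC(C)C(O)CC2CCO)cc2nc(NCc3cccc(Cl)c3)oc12`) keeps the 3-chlorobenzyl group of compound 1 and carries 2-hydroxyethyl in place of hydrogen on a saturated ring carbon, next to the ring nitrogen: 2-hydroxyethyl in place of hydrogen on a saturated ring carbon. Going by the values given here, the measured step sits at a different place in the structure, and no measured pair shows a change on this ring. It therefore gives only weak guidance on size, and no step beyond the scatter is expected in this assay, with the direction left open.

The expected step is a 1.1-fold lower number from compound 1 to compound 3 (0.05 log units; within the scatter). For compound 3 the estimated clearance is 40 mL/min/kg, with an expected range from 20 mL/min/kg to 75 mL/min/kg.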

Compound 3, clearance: 4.5 mL/min/kg
Beside the measured number, compound 3's estimate is 8.9-fold (0.95 log units) above it; measured number outside the range, below it.
By their numbers in this assay, from the lowest: compound 3; then compounds 1 and 2 (each within the scatter of the next).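

In this assay the saturated ring carbon next to the ring nitrogen, on the six-membered non-aromatic ring with 1 nitrogen, turns out to be a sensitive position: 2-hydroxyethyl in place of hydrogen there gives a 10-fold lower number from compound 1 to compound 3 (1.00 log units; beyond the scatter) and so moves the number well beyond the scatter. The only earlier step, a 1.0-fold higher number from compound 1 to compound 2 (0.02 log units; within the scatter) on the group on the nitrogen on an aromatic ring, left the number where it was, so this is the first change in the series shown to shift clearance, and it takes only 3 heavy atoms to do so. Nothing measured on these compounds shows what lies behind the drop.

As far as these compounds go, it remains open whether the effect needs the terminal hydroxy group or only the chain, which a plain ethyl group, a 3-hydroxypropyl chain, a primary amine or a carboxylic acid at the same ring carbon would start to separate. From the compounds shown here alone, it is equally open whether 2-hydroxyethyl at this position would give a step of similar size with the 1-(3-chlorophenyl)cyclopropyl group of compound 2 in place of 3-chlorobenzyl.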